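Replacing a Fluorophenyl Ring with Thiophene

The source may report more compounds than this note shows. Statements on the series, on what has been measured and on what is new or still open speak of the compounds shown alone.

Of the compounds shown here, three sharing one core have been measured in a functional assay on the whole organism (strain Wistar albino) for inhibition, with Rattus norvegicus as the target, read by paw edema, with stated times of 30 min and 2 h, at a dose of 50 mg/kg by the oral route; on this read-out higher numbers stand for more inhibition at the one dose given (going by the name of the read-out) and lower numbers for less inhibition. Compound 1 `NS(=O)(=O)c1ccc2nc(-n3nc(C(F)(F)F)cc3-c3ccc(Cl)cc3)sc2c1` gives 42%. Compound 2 `NS(=O)(=O)c1ccc2nc(-n3nc(C(F)(F)F)cc3-c3ccc4ccccc4c3)sc2c1` gives 27%. Compound 3 `NS(=O)(=O)c1ccc2nc(-n3nc(C(F)(F)F)cc3-c3ccc(F)cc3)sc2c1` gives 48%, the highest of the three numbers, though its gap to compound 1 lies within the scatter, so only compound 2 stands clearly apart from it.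

Compound 4 `NS(=O)(=O)c1ccc2nc(-n3nc(C(F)(F)F)cc3-c3cccs3)sc2c1` is not yet measured. It differs from compound 3 in one place: thiophen-2-yl in place of 4-fluorophenyl on an aromatic carbon.

Going by the values given here, no measured step exchanges the six-membered ring for a five-membered one. The two steps that change this ring, a number 15 percentage points lower from compound 1 to compound 2 (beyond the scatter) and a number 21 percentage points higher from compound 2 to compound 3 (beyond the scatter), show that the larger naphthalen-2-yl group lowers the number, while a number 6 percentage points higher from compound 1 to compound 3 (within the scatter) shows that swapping one halogen for another hardly matters. Compound 4 carries a smaller ring than compound 3, a direction these steps do not cover, so a small drop or no change beyond the scatter is expected, as a number 8 percentage points lower from compound 3 to compound 4 (within the scatter). Compound 4 is therefore estimated to give 40% in this assay, within a range from 25% to 55%.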

Compound 4, a percentage reported as inhibition, in the whole organism at one dose (the size of the read-out at that dose, not a potency): 26%
Beside the measured number, compound 4's estimate is 14 percentage points above it; measured number inside the range.
By their numbers in this assay, from the lowest: compounds 4 and 2 (each within the scatter of the next); then compounds 1 and 3 (each within the scatter of the next).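

The earlier steps shown here showed only that naphthalen-2-yl gave a lower number than the halogen-bearing phenyl rings; in this assay, thiophen-2-yl, with fewer heavy atoms than 4-fluorophenyl, also gives a lower number, with a number 22 percentage points lower from compound 3 to compound 4 (beyond the scatter) and a number 16 percentage points lower from compound 1 to compound 4 (beyond the scatter). Against the naphthalen-2-yl compound there is a number 1 percentage points lower from compound 2 to compound 4 (within the scatter), so among these four compounds, two very different rings on this aromatic carbon read alike, and only 4-chlorophenyl and 4-fluorophenyl stand higher, which means that heavy-atom count alone does not order the numbers here. Nothing available explains why the thiophen-2-yl compound reads as it does.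

The compounds shown leave open how a plain phenyl ring, with no halogen, would read at this position. They also leave open the effect of a phenyl ring carrying a methoxy group, an amine or a carboxylic acid.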